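The compounds below may be only part of what the source reports. "The series", "measured", "known", "first", "only" and "open" are said of these compounds alone.

Compound 1 `Cc1nc(N(C)C(=O)NC(=O)c2c(F)cccc2F)sc1C(=O)N/N=C/c1ccc(F)cc1` in a functional assay on HepG2 cells (Homo sapiens) for inhibition, read by MTT assay, with a stated time of 72 h (on this read-out lower numbers stand for stronger inhibition and higher numbers for weaker inhibition), gives > 100 ug/mL, a limit of the assay.
Compound 2 `CNc1nc(C)c(C(=O)N/N=C/c2ccc(C(F)(F)F)cc2)s1` in this assay gives > 100 ug/mL, a limit of the assay.
Compound 3 `Cc1nc(N(C)C(=O)NC(=O)c2c(F)cccc2F)sc1C(=O)N/N=C/c1ccc(C(F)(F)F)cc1` in this assay gives > 100 ug/mL, a limit of the assay.

Compound 2 thus stands at a limit rather than at a number, and every value shown sits at the limit of > 100 ug/mL in this assay, at which 3 of the 3 values shown sit. Compound 4 `CNc1nc(C(F)(F)F)c(C(=O)N/N=C/c2ccc(C(F)(F)F)cc2)s1` differs from compound 2 by trifluoromethyl in place of methyl on an aromatic carbon. Among the measured compounds shown here, the one measured step, a step that the two limits leave unreadable from compound 1 to compound 3, runs between two limits and so gives no size; it concerns a different position and a different change. For the measured compounds named here, no measured step therefore bears on the change from compound 2 to compound 4, and no step beyond the scatter can be expected in this assay in either direction. Compound 4 is expected to give about 150 ug/mL in this assay, within 50 ug/mL to 500 ug/mL. This estimate means a step that the limit leaves unreadable from compound 2 to compound 4, most likely again reported only as a limit.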

Compound 4, half-maximal inhibitory concentration: > 100 ug/mL
Compound 4: no number, only a limit (the forecaster's own chance of this, stated with the estimate: 75%); the middle value does not contradict the limit.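

Among the compounds shown here, compound 2 and compound 4 both give only a limit, so no step between them can be read in this assay. The compounds shown leave open whether any of these changes alters inhibition, because none yields a number: the limit of > 100 ug/mL in this assay, at which 4 of the 4 values shown sit.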